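Adding a Methyl to the Benzyl Chain of Compound 3

The compounds below may be only part of what the source reports. "The series", "measured", "known", "first", "only" and "open" are said of these compounds alone.

In a functional assay on A549 cells (Homo sapiens) for cytotoxicity, read by MTT assay, with a stated time of 72 h (on this read-out lower numbers stand for stronger inhibition and higher numbers for weaker inhibition), compound 3 `[O-][n+]1nc(NCOCc2ccccc2)[n+]([O-])c2ccccc21` gives 10800 nM, the highest of the three numbers. Compound 1 `[O-][n+]1nc(NCOC2CCCCC2)[n+]([O-])c2ccccc21` gives 5180 nM and compound 2 `COc1ccc2c(c1)[n+]([O-])nc(NCOCc1ccccc1)[n+]2[O-]` gives 2500 nM; the two measured steps are a 2.1-fold higher number from compound 1 to compound 3 (0.32 log units; beyond the scatter) and a 4.3-fold higher number from compound 2 to compound 3 (0.64 log units; beyond the scatter), and both leave compound 3 as the weakest. Compound 4 `CC(OCNc1n[n+]([O-])c2ccccc2[n+]1[O-])c1ccccc1` differs from compound 3 by methyl in place of hydrogen on a saturated chain carbon bound to an aromatic carbon and an oxygen on a saturated carbon. Neither measured step touches this saturated chain carbon: one exchanges a cyclohexyl for a benzyl, the other removes a methoxy from the aromatic ring. With no comparable change measured, the expected step is small, within or near the scatter, a 1.4-fold lower number from compound 3 to compound 4 (0.13 log units; within the scatter). Compound 4 is estimated at 8000 nM, with a range from 3500 nM to 20000 nM.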

Compound 4, half-maximal inhibitory concentration: 2710 nM
Compound 4: middle estimate off by 3.0-fold (0.47 log units), on the high side; measured number outside the range, below it.
By their numbers in this assay, from the lowest: compounds 2, 4 and 1 (each within the scatter of the next, the first and the last beyond it); then compound 3.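

In this assay, the saturated chain carbon bound to an aromatic carbon and an oxygen on a saturated carbon proves responsive to change: methyl in place of hydrogen gives a 4.0-fold lower number from compound 3 to compound 4 (0.60 log units; beyond the scatter). A single added carbon, with no ring and no hydrogen-bond donor or acceptor, is enough to move the number beyond the scatter. No measurement at hand explains this step. Going by these compounds, whether an ethyl or a hydroxyl on this carbon would lower the number further remains open. So does whether this methyl and the methoxy of compound 2 would work together in one molecule.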